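A few compounds are considered here, and "the series" means these few. Any claim that something is new, unique, unknown or untested is made for them only; others in the source may bear on it.

Compound 1 `O=[N+]([O-])c1cn2c(n1)OCC(COc1ccc(-c3ccc(OC(F)(F)F)cc3)cc1)C2`: in an ADME assay on Vero cells (Chlorocebus sabaeus) for cytotoxicity, with a stated time of 72 h (a higher number here means a weaker inhibitor, a lower number a stronger inhibitor), compound 1 gives > 128000 nM, which is a limit of the assay and not a number.
Compound 2 `O=[N+]([O-])c1cn2c(n1)OCC(COc1ccc(-c3ccc(C(F)(F)F)cc3)cc1)C2`: in this assay compound 2 gives > 128000 nM, again a limit rather than a number.
Compound 3 `O=[N+]([O-])c1cn2c(n1)OCC(COCc1ccc(-c3ccc(OC(F)(F)F)cc3)cc1)C2`: in this assay compound 3 gives > 128000 nM, also a limit and not a number.

The change from compound 1 to compound 2 is trifluoromethyl in place of trifluoromethoxy on an aromatic carbon. The step it made in this assay is a step that the two limits leave unreadable from compound 1 to compound 2, and its size cannot be read because of the limit of > 128000 nM in this assay, at which 3 of the 3 values shown sit. Compound 3 carries a different core from compound 1; how the two cores differ is not broken down here, and both values are limits.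

Compound 4 `O=[N+]([O-])c1cn2c(n1)OCC(COCc1ccc(-c3ccc(C(F)(F)F)cc3)cc1)C2` has not been measured in this assay. For the measured compounds named here, it differs from compound 3 by trifluoromethyl in place of trifluoromethoxy on an aromatic carbon, the same change as the one made from compound 1 to compound 2, at a place described in the same words. Going by the values given here, since every value so far is a limit, the earlier step gives no readable size to carry over; the expectation for compound 4 rests on the fact that (the limit of > 128000 nM in this assay, at which 3 of the 3 values shown sit).

Compound 4 is therefore expected to sit at the limit as well, with an estimate of 150000 nM in this assay. The range expected for compound 4 runs from 100000 nM to 300000 nM. The step this estimate implies is a step that the limit leaves unreadable from compound 3 to compound 4, which is expected to be unreadable in the same way as the earlier one.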

Compound 4, half-maximal inhibitory concentration: 38000 nM
Compound 4: the middle estimate sits 3.9-fold (0.60 log units) above what was measured; measured number below the stated range.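

In this assay, going by these compounds, trifluoromethyl in place of trifluoromethoxy gave an at least 3.3-fold lower number from compound 3 to compound 4 (0.52 log units; beyond the scatter), a step that can be read even though its true size stays open, as its starting value is a limit and not a number. The same change on the core of compound 1 cannot be read, and this holds for every step between two limits in the series: the limit of > 128000 nM in this assay, at which 3 of the 4 values shown sit. The result therefore shows that the change can lower the number on one of the two cores, but it does not show that the change carries from one core to the other or that it acts differently on them, as the earlier step offers no size to set against this one.

The compounds shown leave open whether the lower number belongs to trifluoromethyl in particular or would also appear with a nitrile, a chlorine atom or a carboxylic acid at the same place, para to a large group. They also leave open whether an amine at that place, or a longer chain in the link to the shared core, would bring a readable number on either core.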